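A Third Methoxy on the Carbonyl-Side Ring

The source may hold more compounds than are shown below. What is called first, only, known or untested is meant among the compounds shown, and "the series" means these compounds.

Compound 1 `COc1cc(-c2cc(/C=C/C(=O)c3ccc(N)cc3)[nH]n2)cc(OC)c1OC` gives 66% in a functional assay on MCF7 cells (Homo sapiens) for cytotoxicity, read by sulforhodamine B assay, with a stated time of 48 h, tested at 1 uM; on this read-out higher numbers stand for a weaker effect at the one concentration tested and lower numbers for a stronger effect.
Compound 2 `COc1ccc(C(=O)/C=C/c2cc(-c3cc(OC)c(OC)c(OC)c3)n[nH]2)cc1OC` gives 31% in this assay.
Compound 3 `COc1cc(-c2cc(/C=C/C(=O)c3ccc(F)c(F)c3)[nH]n2)cc(OC)c1OC` gives 99% in this assay.

In this assay compound 2 stands lowest of the three numbers, and the steps of a number 35 percentage points lower from compound 1 to compound 2 (beyond the scatter) and a number 68 percentage points higher from compound 2 to compound 3 (beyond the scatter) both lie beyond the scatter. Compound 4 `COc1cc(C(=O)/C=C/c2cc(-c3cc(OC)c(OC)c(OC)c3)n[nH]2)cc(OC)c1OC` differs from compound 2 by methoxy in place of hydrogen on an aromatic carbon, the new group sitting ortho to a methoxy group and meta to a methoxy group. Among the compounds with values here, both measured steps exchange the whole ring on the carbonyl carbon; none adds a methoxy to a ring already carrying two, so no measured step bears directly on this change. Compound 4 is therefore expected to show a number 4 percentage points higher from compound 2 to compound 4 (within the scatter), a step within the scatter. The estimate for compound 4 in this assay is 35%, between 15% and 60%.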

Compound 4, a percentage reported as activity, at one concentration (the size of the read-out at that concentration, not a potency): 40%
Compound 4: middle estimate off by 5 percentage points, on the low side; the range from low to high includes it.
By their numbers in this assay, from the lowest: compounds 2 and 4 (each within the scatter of the next); then compound 1; then compound 3.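

In this assay, methoxy in place of hydrogen on this aromatic carbon, ortho to a methoxy group and meta to a large group, gives a number 9 percentage points higher from compound 2 to compound 4 (within the scatter) and so does not separate the two compounds. The earlier steps shown here exchanged the whole ring on the carbonyl carbon and all lay beyond the scatter, whereas this single added group on the retained ring does not. Nothing available here explains this result.

Going by these compounds, whether a hydroxyl group or a chlorine atom on this same carbon would also stay within the scatter of compound 2 remains open. So does whether methoxy here would give a similar step on the difluorinated ring of compound 3 or the amino-bearing ring of compound 1.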